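Extending the sulfur substituent from compound 3 to compound 4

The source may hold more compounds than are shown below. What is called first, only, known or untested is meant among the compounds shown, and "the series" means these compounds.

Compound 3 `CC(C)c1n[nH]c2c(NCc3ccc(-c4ccccn4)cc3)nc(S)nc12` gives 2760 nM in a functional assay on HT cells (Homo sapiens) for antiproliferative activity, read by fluorescence, with a stated time of 72 h (on this read-out lower numbers stand for stronger inhibition of growth and higher numbers for weaker inhibition of growth), the highest number among the three measured compounds. Compound 2 `C=CCSc1nc(NCc2ccc(-c3ccccn3)cc2)c2[nH]nc(C(C)C)c2n1` gives 1010 nM and compound 1 `CC(C)c1n[nH]c2c(NCc3ccc(-c4ccccn4)cc3)nc(SC[C@H](O)CN)nc12` gives 63 nM. Compound 4 `CCC(CO)Sc1nc(NCc2ccc(-c3ccccn3)cc2)c2[nH]nc(C(C)C)c2n1` differs from compound 3 by 1-(hydroxymethyl)propyl in place of hydrogen on a sulfur. Within the data shown here, two measured steps bear on this change: a 2.7-fold higher number from compound 2 to compound 3 (0.44 log units; beyond the scatter) and a 44-fold higher number from compound 1 to compound 3 (1.64 log units; beyond the scatter). In both, a group on the sulfur goes with a lower number, and the 3-amino-2-hydroxypropyl of compound 1 does so far more than the allyl of compound 2. The 1-(hydroxymethyl)propyl group shares a hydrogen-bond donor with the chain of compound 1 but not its amino part, so compound 4 is expected to land between those two, a 9.2-fold lower number from compound 3 to compound 4 (0.96 log units; beyond the scatter). Compound 4 is therefore estimated at 300 nM, with a range from 100 nM to 900 nM.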

Compound 4, concentration for 50% growth inhibition: 255 nM
For compound 4 the middle estimate is 1.2-fold (0.07 log units) above the measured one, and the stated range covers the measured number.
By their numbers in this assay, from the lowest: compound 1; then compound 4; then compound 2; then compound 3.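

In this assay, among these compounds, putting 1-(hydroxymethyl)propyl on the sulfur gives an 11-fold lower number from compound 3 to compound 4 (1.03 log units; beyond the scatter) and is the first change to show that a chain with a hydroxyl but no amino group can achieve a large gain. The same group outperforms allyl, with a 4.0-fold lower number from compound 2 to compound 4 (0.60 log units; beyond the scatter) as the step. It still falls short of 3-amino-2-hydroxypropyl, with a 4.0-fold higher number from compound 1 to compound 4 (0.61 log units; beyond the scatter) as the step, so only part of the gain of compound 1 is retained.

From the compounds shown here alone, whether a chain carrying an amine without the hydroxyl, a carboxylic acid or a longer chain would match compound 1 remains open. Nothing available here explains these differences.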